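This account rests on a few compounds, and the source may have more. Where it says the series, first, only, none or still open, it means among the compounds named here.

Measured compounds in a functional assay on HT-29 cells (Homo sapiens) for cytotoxicity, read by neutral red uptake, with a stated time of 72 h; on this read-out lower numbers stand for stronger inhibition and higher numbers for weaker inhibition: compound 1 `CCCCCCCNc1nc(SCC)nc2ncccc12` gives 19900 nM; compound 2 `CCCCCNc1nc(SC(C)C)nc2ncccc12` gives 25200 nM; compound 3 `CCCCCCNc1nc(SC(C)C)nc2ncccc12` gives 20200 nM.

Compound 3 stands second highest of the three numbers in this assay. Its nearest neighbour is compound 1, and compound 2 lies furthest from it, but both gaps are within the scatter, so the three measured compounds read as one level.

Compound 4 `CCCCCCCNc1nc(SC(C)C)nc2ncccc12` has not been measured. It differs from compound 3 by methyl in place of hydrogen on a saturated chain carbon, six bonds along the chain from a nitrogen on an aromatic ring. Going by the values given here, the only measured step of the same kind is the one within the chain by one carbon, from compound 2 to compound 3, which gave a 1.2-fold lower number from compound 2 to compound 3 (0.10 log units; within the scatter). That step bears directly on the present one, being the same change cut one bond nearer the ring nitrogen, and it did not move the number beyond the scatter. Compound 1 carries the same longer chain as compound 4 with a different sulfur substituent; its value and that of compound 3 sit within the scatter of each other, which does not argue for a shift either.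

For compound 4 in this assay no step beyond the scatter is therefore expected, the estimated step being a 1.1-fold lower number from compound 3 to compound 4 (0.03 log units; within the scatter). Compound 4 is expected to give about 19000 nM, within the range 10000 nM to 38000 nM.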

Compound 4, half-maximal inhibitory concentration: 24400 nM
The estimate for compound 4 lay 1.3-fold (0.11 log units) below the measured number; low and high end bracket the measured number.
By their numbers in this assay, from the lowest: compounds 1, 3, 4 and 2 (each within the scatter of the next).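

In this assay, methyl in place of hydrogen on a saturated chain carbon, six bonds along the chain from a nitrogen on an aromatic ring, leaves the number level (a 1.2-fold higher number from compound 3 to compound 4 (0.08 log units; within the scatter)), so this place in the chain reads like the place one bond nearer. The larger change on this chain also stays level (a 1.0-fold lower number from compound 2 to compound 4 (0.01 log units; within the scatter)), so it shows no step beyond the scatter either. Methyl in place of hydrogen on a saturated chain carbon bound to a saturated chain carbon and a sulfur gives the same reading (a 1.2-fold higher number from compound 1 to compound 4 (0.09 log units; within the scatter)), and the methyl steps on the two cores agree: the same change on two cores in this assay, a 1.2-fold lower number (0.10 log units; within the scatter) from compound 2 to compound 3 and a 1.2-fold higher number (0.09 log units; within the scatter) from compound 1 to compound 4, 1.5-fold (0.18 log units) apart, within the scatter of two such steps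

Going by these compounds, all four compounds carry plain saturated chains, so it stays open whether an amine or a carboxylic acid on the nitrogen-bound chain, or a much longer chain, would move the number beyond the scatter in this assay at all. On these data alone, it also stays open whether a chlorine on the shared core would shift this level.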